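A few compounds are considered here, and "the series" means these few. Any claim that something is new, unique, unknown or untested is made for them only; others in the source may bear on it.

Three compounds with the same core have been examined in a functional assay on the whole organism (Tail, strain ICR) with Mus musculus as the target, in the tail flick test, with a stated time of 60 min, at a dose of 25 umol/kg by the oral route; a lower number here means a weaker effect, a higher number a stronger effect of the compound at the dose given. Compound 1 `CC(C)[C@H](NC(=O)CN(c1nc(Cl)nc2[nH]cnc12)C1CC1)C(=O)OCc1ccccc1` gives 55.5%, compound 2 `NC(=O)C[C@H](NC(=O)CN(c1nc(Cl)nc2[nH]cnc12)C1CC1)C(=O)O` gives 43.1%, and compound 3 `CC(C)C[C@H](NC(=O)CN(c1nc(Cl)nc2[nH]cnc12)C1CC1)C(=O)OCc1ccccc1` gives 27.3%. Within the data shown here, compound 3 thus stands lowest of the three in this assay, and the one step on record, a number 28.2 percentage points lower from compound 1 to compound 3 (beyond the scatter), is the change of isobutyl in place of isopropyl that separates compound 3 from compound 1.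

Compound 4 `NC(=O)C[C@H](NC(=O)CN(c1nc(Cl)nc2[nH]cnc12)C1CC1)C(=O)OCc1ccccc1` is reached from compound 3 by a change at the same chain position: carbamoyl in place of isopropyl on a saturated chain carbon, two bonds along the chain from an amide-type nitrogen and a carbonyl carbon. Among the measured compounds shown here, no measured step carries this exact change. The nearest guide is compound 2, which bears the carbamoylmethyl chain but a free acid rather than the benzyl ester, and in this assay compound 2 gives 43.1%, a higher number than compound 3 shows. A rise, modest but beyond the scatter, is therefore expected, so the step of a number 17.7 percentage points higher from compound 3 to compound 4 (beyond the scatter) is the estimate. For compound 4 the expected activity in this assay is 45%, within a range from 25% to 65%.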

Compound 4, a percentage reported as activity, at one dose (the size of the read-out at that dose, not a potency): 36.4%
For compound 4 the middle estimate is 8.6 percentage points above the measured one, and the stated range covers the measured number.
By their numbers in this assay, from the lowest: compounds 3, 4 and 2 (each within the scatter of the next, the first and the last beyond it); then compound 1.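

With the benzyl ester kept, the change from isobutyl to carbamoylmethyl gives a number 9.1 percentage points higher from compound 3 to compound 4 (within the scatter) in this assay and so does not separate these two chains at this position. With the carbamoylmethyl chain kept, the benzyl ester in place of the free acid gives a number 6.7 percentage points lower from compound 2 to compound 4 (within the scatter) and does not separate those two ends of the molecule either. The chain can still count, since carbamoylmethyl in place of isopropyl gives a number 19.1 percentage points lower from compound 1 to compound 4 (beyond the scatter) and compound 1 stays apart from both compound 3 and compound 4 in this series.

Nothing available explains these differences. Still open, on these data alone, is how an amine or a longer chain at this position would compare with isopropyl in the benzyl ester series.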